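The source may report more compounds than this note shows. Statements on the series, on what has been measured and on what is new or still open speak of the compounds shown alone.

Measured compounds:
compound 1, `COc1cc(Nc2ccnc(NCCNc3ccnc4cc(Cl)ccc34)n2)cc(OC)c1`: in an ADME assay on Vero cells (Chlorocebus sabaeus) for cytotoxicity, read by neutral red uptake, with a stated time of 72 h (a higher number here means a weaker inhibitor, a lower number a stronger inhibitor), compound 1 is reported as "not active" (no number reported), with no number given
compound 2, `Clc1ccc2c(NCCCCNc3nccc(Nc4ccccc4)n3)ccnc2c1`: in this assay compound 2 gives 14300 nM

Among the compounds with values here, compound 2 therefore stands as the only compound of the pair with a measured value in this assay; compound 1 gives no single number there, only a statement that it is not active, so the two cannot be placed against each other by size.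

Compound 3, `Fc1ccc(Nc2ccnc(NCCCCNc3ccnc4cc(Cl)ccc34)n2)cc1`, has not yet been measured. It differs from compound 2 in one place: fluoro in place of hydrogen on an aromatic carbon. Within the data shown here, no step between measured compounds is available for this kind of change, so nothing in the data shows how large a shift it brings. In the absence of such a reference, the expectation is that compound 3 stays close to compound 2, with a step of a 1.0-fold lower number from compound 2 to compound 3 (0.01 log units; within the scatter) that should not exceed the usual scatter in either direction. Compound 3 is thus expected to give about 14000 nM in this assay, within a range from 6000 nM to 35000 nM.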

Compound 3, half-maximal inhibitory concentration: "not active" (no number reported)
For compound 3 the study gives words and no number, so the estimate cannot be set against anything.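

In this assay, within the data shown here, compound 3 is reported only in words, while compound 2 gives 14300 nM, so no step from compound 2 to compound 3 can be read. Nothing measured here bears on this result. The compounds shown leave open how far fluoro in place of hydrogen shifts the number in this assay.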